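A few compounds are considered here, and "the series" means these few. Any claim that something is new, unique, unknown or untested is made for them only; others in the source may bear on it.

Three compounds were measured in a functional assay on HT-29 cells (Homo sapiens) for cytotoxicity, read by MTT assay, with a stated time of 2 days, tested at 10 uM; a lower number here means less inhibition, a higher number more inhibition at the concentration tested (going by the name of the read-out). Compound 1, with the structure `Cc1cccc(N2CCN(CCCNc3nc(NCc4ccco4)c4ccccc4n3)CC2)c1C`, gives 94%. Compound 2, with the structure `Clc1cccc(N2CCN(CCCNc3nc(NCc4ccco4)c4ccccc4n3)CC2)c1Cl`, gives 94.1%. Compound 3, with the structure `Clc1cccc(N2CCN(CCCCNc3nc(NCc4ccco4)c4ccccc4n3)CC2)c1Cl`, gives 94.8%. All three numbers lie within the usual scatter of one another, so no ordering among them can be read from these data.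

Compounds 2 and 1 differ in one place, a change described as 2,3-dimethylphenyl in place of 2,3-dichlorophenyl on an amine nitrogen in a ring, and the measured step is a number 0.1 percentage points lower from compound 2 to compound 1 (within the scatter). How the core of compound 3 differs from the core of compound 2 is not broken down here.

Compound 4, with the structure `Cc1cccc(N2CCN(CCCCNc3nc(NCc4ccco4)c4ccccc4n3)CC2)c1C`, has not yet been measured. Among the measured compounds shown here, it differs from compound 3 by 2,3-dimethylphenyl in place of 2,3-dichlorophenyl on an amine nitrogen in a ring, the same change, at the same place, as the one between compounds 2 and 1. The step from compound 3 to compound 4 is therefore expected to be small, estimated as a number 0.3 percentage points lower from compound 3 to compound 4 (within the scatter), an expectation that rests on the near-zero measured step a number 0.1 percentage points lower from compound 2 to compound 1 (within the scatter) for the identical change. Compound 4 is estimated to give 94.5% in this assay, with a plausible range from 89% to 98%.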

Compound 4, a percentage reported as inhibition, at one concentration (the size of the read-out at that concentration, not a potency): 94.2%
For compound 4 the middle estimate is 0.3 percentage points above the measured one; measured number inside the range.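

In this assay, putting 2,3-dimethylphenyl in place of 2,3-dichlorophenyl gives a number 0.6 percentage points lower from compound 3 to compound 4 (within the scatter), so this change again leaves no readable difference on a second core. Set side by side, the two cases agree: the same change on two cores in this assay, a number 0.1 percentage points lower (within the scatter) from compound 2 to compound 1 and a number 0.6 percentage points lower (within the scatter) from compound 3 to compound 4, 0.5 percentage points apart, within the scatter of two such steps. This shows that, at the single concentration tested, the change carried over between these two cores without a visible effect, but it does not show that the two groups would have an equally strong effect at any other concentration, and two cores do not make a rule for the whole series.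

Still open is how a plain phenyl or a methoxyphenyl group on the same ring nitrogen would compare with the two groups shown. Also open, on these data alone, is whether the same change would stay this small on a core with a longer chain, or at a lower concentration, where compounds that read alike here might separate.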